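This account rests on a few compounds, and the source may have more. Where it says the series, first, only, none or still open, it means among the compounds named here.

Compound 3, `Cc1nc(-c2nc3ccccc3n2Cc2ccccc2)sc1C(=O)O`, stands only at a limit: in a functional assay on MCF7 cells (Homo sapiens) for cytotoxicity, read by MTT assay, with a stated time of 24 h (a higher number here means a weaker inhibitor, a lower number a stronger inhibitor), compound 3 gives > 20000 nM, a limit of the assay rather than a number. Compound 1, `CCOC(=O)c1sc(-c2nc3ccccc3n2Cc2ccccc2)nc1C`, gives in this assay likewise a limit, > 20000 nM. Compound 2, `CCOC(=O)c1csc(-c2nc3ccccc3n2C)n1`, gives in this assay a limit too, > 20000 nM. Going by the values given here, the one measured step, a step that the two limits leave unreadable from compound 1 to compound 3, cannot be read because the limit of > 20000 nM in this assay, at which 3 of the 3 values shown sit, holds every value shown. Compound 4, `Cc1nc(-c2nc3ccccc3n2Cc2ccccc2)sc1C(=O)NC(C)C`, differs from compound 3 by isopropylamino in place of hydroxy on a carbonyl carbon. Among the compounds with values here, no measured step bears on this change, and the values of compounds 1 and 2 show only limits, so neither size nor direction of the step in this assay can be foreseen. Compound 4 is therefore expected to sit near the same limit, at an estimated 30000 nM (between 8000 nM and 120000 nM). The expected step is a step that the limit leaves unreadable from compound 3 to compound 4.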

Compound 4, half-maximal inhibitory concentration: 6640 nM
Estimate against measurement, compound 4: 4.5-fold (0.65 log units) above; the whole stated range lies above it.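

Among the compounds shown, only compound 4 gives a number rather than a limit in this assay, so this carbonyl carbon is a place where a change can be read. Isopropylamino in place of hydroxy gives an at least 3.0-fold lower number from compound 3 to compound 4 (0.47 log units; beyond the scatter), and isopropylamino in place of ethoxy gives an at least 3.0-fold lower number from compound 1 to compound 4 (0.47 log units; beyond the scatter). Both sizes are minimums, and the other compounds offer no second number: the limit of > 20000 nM in this assay, at which 3 of the 4 values shown sit.

Going by these compounds, whether a longer chain or a cyclic amine such as morpholine on this carbonyl carbon would lower the number further remains open. So does whether a dimethylamino group, which lacks the amide hydrogen, would do the same.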